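The compounds below may be only part of what the source reports. "The series", "measured", "known", "first", "only" and "open" are said of these compounds alone.

The measured compounds, in a functional assay for inhibition of sodium/hydrogen exchanger (Oryctolagus cuniculus); on this read-out lower numbers stand for stronger inhibition and higher numbers for weaker inhibition:

- compound 1, `CCc1cc(Cl)c(S(C)(=O)=O)cc1C(=O)N=C(N)N`: compound 1 gives 63 nM
- compound 2, `CS(=O)(=O)c1cc(C(=O)N=C(N)N)c(F)cc1F`: compound 2 gives 630 nM
- compound 3, `Cc1cc(C2CCC2)c(S(C)(=O)=O)cc1C(=O)N=C(N)N`: compound 3 gives 8.2 nM

Of these three, compound 3 stands at the lowest number. The nearest value is that of compound 1, and that gap lies beyond the usual scatter of this assay; the furthest is that of compound 2, which lies even further beyond it. All three share a core with an acylguanidine and a methylsulfonyl group, and they differ in the substituents on the aromatic ring.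

Compound 4, `CCOc1cc(C)c(C(=O)N=C(N)N)cc1S(C)(=O)=O`, is not yet measured in this assay. It differs from compound 3 in a single place: ethoxy in place of cyclobutyl on an aromatic carbon

For the measured compounds named here, no pair of measured compounds differs in only one place, so the effect of this exchange has to be judged without a directly comparable step. The change brings an oxygen-containing chain in place of a carbon ring at the same position. Compound 4 is expected to remain among the lower numbers of this set, but a moderate move toward a weaker inhibition, beyond the scatter, is the more likely outcome, described by a 3.0-fold higher number from compound 3 to compound 4 (0.48 log units; beyond the scatter) as an estimated step. For compound 4 the estimated value in this assay is 25 nM, with an expected range from 8 nM to 80 nM.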

Compound 4, half-maximal inhibitory concentration: 19 nM
The estimate for compound 4 lay 1.3-fold (0.12 log units) above the measured number, within the range that was stated.
By their numbers in this assay, from the lowest: compound 3; then compound 4; then compound 1; then compound 2.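

In this assay, for the compounds shown here, the exchange of cyclobutyl for ethoxy provides the only step in this set that can be read at a single place: a 2.3-fold higher number from compound 3 to compound 4 (0.36 log units; beyond the scatter), a modest loss that nevertheless lies beyond the scatter. It shows that a low number at this position, on an aromatic carbon ortho to a methylsulfonyl group and para to a group of 6 heavy atoms, does not require a four-membered carbon ring, since compound 4, with an open ethoxy chain, still gives 19 nM. No measurement bears on the reason for this step, and this single exchange cannot separate the loss of the ring from the entry of the oxygen.

The compounds shown leave open how a propyl chain, which has no oxygen and no ring, or a longer ether such as butoxy, or an amine would read at this same position in this assay. They also leave open whether the step would keep its size if the methyl group on the ring were replaced by another group.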